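Replacing 3,5-dibromo-4-hydroxyphenyl with 2,3,4-trimethoxyphenyl

A few compounds are considered here, and "the series" means these few. Any claim that something is new, unique, unknown or untested is made for them only; others in the source may bear on it.

In a functional assay on HeLa cells (Homo sapiens) for cytotoxicity, read by MTT assay, with a stated time of 72 h (a higher number here means a weaker inhibitor, a lower number a stronger inhibitor), compound 1 `COc1cc(/C=C/C(=O)Nc2cc3c(Nc4ccc(F)c(Cl)c4)ncnc3cc2O[C@H]2CCOC2)cc(OC)c1OC` gives 24500 nM and compound 2 `O=C(/C=C/c1cc(Br)c(O)c(Br)c1)Nc1cc2c(Nc3ccc(F)c(Cl)c3)ncnc2cc1O[C@H]1CCOC1` gives 27700 nM as its reading, so compound 2 stands level with compound 1 within the scatter. Compound 3 `COc1ccc(/C=C/C(=O)Nc2cc3c(Nc4ccc(F)c(Cl)c4)ncnc3cc2O[C@H]2CCOC2)c(OC)c1OC` keeps the rest of compound 2 but carries 2,3,4-trimethoxyphenyl in place of 3,5-dibromo-4-hydroxyphenyl (2,3,4-trimethoxyphenyl in place of 3,5-dibromo-4-hydroxyphenyl on a double-bonded chain carbon bound to a double-bonded chain carbon) on a double-bonded chain carbon bound to a double-bonded chain carbon. Going by the values given here, only one measured step bears on this place: it exchanged 3,4,5-trimethoxyphenyl for 3,5-dibromo-4-hydroxyphenyl and came to a 1.1-fold higher number from compound 1 to compound 2 (0.05 log units; within the scatter) in size. On that evidence, no step beyond the scatter is expected in this assay and no direction can be favoured. The estimated step is a 1.1-fold lower number from compound 2 to compound 3 (0.04 log units; within the scatter) at its middle. For compound 3 the expected value is 25000 nM with an estimated range from 12000 nM to 50000 nM overall.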

Compound 3, half-maximal inhibitory concentration: 4830 nM
Estimate against measurement, compound 3: 5.2-fold (0.71 log units) above; measured number outside the range, below it.
By their numbers in this assay, from the lowest: compound 3; then compounds 1 and 2 (each within the scatter of the next).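

In this assay the group at this place on the double-bonded chain carbon is shown to matter: 2,3,4-trimethoxyphenyl in place of 3,5-dibromo-4-hydroxyphenyl gives a 5.7-fold lower number from compound 2 to compound 3 (0.76 log units; beyond the scatter), whereas the earlier exchange of aryl groups stayed within the scatter. The arrangement of the methoxy groups also counts, since 2,3,4-trimethoxyphenyl in place of 3,4,5-trimethoxyphenyl gives a 5.1-fold lower number from compound 1 to compound 3 (0.71 log units; beyond the scatter), a change that keeps the kind of substituent and alters only its pattern on the ring. Nothing available here bears on why these numbers fall.

Still open, as far as these compounds go, is whether all the methoxy groups of 2,3,4-trimethoxyphenyl are needed, or whether a ring with a single methoxy group would give a similar number. From the compounds shown here alone, it is equally open how an amine or a carboxylic acid on this ring would fare.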